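Aryl Ether to Aryl Ketone on the Shared Core

The source may hold more compounds than are shown below. What is called first, only, known or untested is meant among the compounds shown, and "the series" means these compounds.

Measured so far in an assay on isolated protein for binding affinity to 5-hydroxytryptamine receptor 7 (Homo sapiens); on this read-out higher numbers stand for weaker inhibition and lower numbers for stronger inhibition:

Compound 1: `O=C1CC(CN2CCC(Oc3ccccc3)CC2)CCc2ccccc21`, compound 1 gives 18.6 nM
Compound 2: `O=C1c2ccccc2CCCN1CCN1CCC(Oc2ccc(Cl)cc2)CC1`, compound 2 gives 11.8 nM

Compound 2 has the lower of the two numbers recorded in this assay, but the value of compound 1 sits within the usual scatter of it, so the two cannot be ordered and neither can be called the stronger binder on these data alone.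

Compound 3, `O=C(c1ccc(Cl)cc1)C1CCN(CCN2CCCc3ccccc3C2=O)CC1`, has not yet been measured. It differs from compound 2 in one place: (4-chlorophenyl)carbonyl in place of 4-chlorophenoxy on a saturated ring carbon. For the measured compounds named here, no pair of measured compounds differs in this same way, so there is no measured step from which the size of this change could be read off directly.

With nothing in the data pointing either way, the change from compound 2 to compound 3 is expected to produce a step of at most modest size, most likely none beyond the scatter, and the step of a 1.3-fold higher number from compound 2 to compound 3 (0.10 log units; within the scatter) is the author's estimate rather than a measured result. Compound 3 is therefore expected to give about 15 nM in this assay, with a range from 4 nM to 60 nM.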

Compound 3, inhibition constant: 2.51 nM
Compound 3: the middle estimate sits 6.0-fold (0.78 log units) above what was measured, outside the stated range (below it).
By their numbers in this assay, from the lowest: compound 3; then compounds 2 and 1 (each within the scatter of the next).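

In this assay, for the compounds shown here, (4-chlorophenyl)carbonyl in place of 4-chlorophenoxy on a saturated ring carbon gives a 4.7-fold lower number from compound 2 to compound 3 (0.67 log units; beyond the scatter), the first step in this set to lie beyond the scatter. This shows that the group at this place, three ring bonds from the ring nitrogen, can shift the number, which compound 1 and compound 2 could not show, as they differ in more than one place and stand within the scatter of each other. The step comes with little change in what is counted: both groups have one six-membered aromatic ring of carbon only, 0 hydrogen-bond donors and 1 hydrogen-bond acceptor, while the entering group has 9 heavy atoms against 8 and 1 double bond outside aromatic rings, and nothing available here accounts for the step.

The compounds shown leave open whether a methylene link, a hydroxyl-bearing carbon or an amine link in place of the carbonyl would give a similar number. They also leave open whether the step would persist with a fluorine or a hydrogen in place of the chlorine, or with the same exchange on the core of compound 1.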